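This account rests on a few compounds, and the source may have more. Where it says the series, first, only, none or still open, it means among the compounds named here.

Measured compounds and their values in an assay on isolated protein for inhibition of histone deacetylase 4 (Homo sapiens), with a stated time of 1 h; a higher number here means a weaker inhibitor, a lower number a stronger inhibitor:
- compound 1 `O=C(CN1C(=O)S/C(=C/c2ccccn2)C1=O)Nc1nc2ccccc2s1` gives 9300 nM
- compound 2 `COc1cccc(NC(=O)COc2ccc3cc(/C=C4/SC(=O)NC4=O)ccc3c2)c1` gives 1600 nM
- compound 3 `O=C(COc1ccc2cc(/C=C3/SC(=O)NC3=O)ccc2c1)Nc1ccccc1Oc1ccccc1` gives 5200 nM

Of these three, compound 2 has the lowest number and is the strongest inhibitor shown; its gaps to compound 3 and to compound 1 both lie beyond the usual scatter. Compound 4 `O=C(COc1ccc2cc(/C=C3/SC(=O)NC3=O)ccc2c1)Nc1ccc(F)cc1F` keeps the shared core of compound 2 and differs in one place: 2,4-difluorophenyl in place of 3-methoxyphenyl on an amide-type nitrogen. For the measured compounds named here, no measured pair shows this exact change, so its effect can only be estimated. Compared with compound 3, the other compound built on the same core, compound 2 is the stronger of the two, and a swap of the group on the amide nitrogen is expected to move the number only modestly, perhaps toward a weaker inhibitor, as in the expected step of a 1.6-fold higher number from compound 2 to compound 4 (0.19 log units; within the scatter). Compound 4 is therefore estimated at 2500 nM, with a likely range from 900 nM to 7000 nM.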

Compound 4, half-maximal inhibitory concentration: 3900 nM
Compound 4: middle estimate off by 1.6-fold (0.19 log units), on the low side; measured number inside the range.
By their numbers in this assay, from the lowest: compound 2; then compounds 4, 3 and 1 (each within the scatter of the next, the first and the last beyond it).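

For the compounds shown here, on the amide-type nitrogen, putting 2,4-difluorophenyl in place of 3-methoxyphenyl gives the first direct one-place comparison in this assay, with a 2.4-fold higher number from compound 2 to compound 4 (0.39 log units; beyond the scatter). This shows that the group at this position affects inhibition and that this swap weakens it. The numbers cannot separate losing the methoxy from adding the fluorines, and nothing measured here explains the shift.

As far as these compounds go, it remains open how an unsubstituted phenyl or a single fluorine would compare. Whether an amine or carboxylic acid on this ring could lower the number is also unresolved.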